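Aryl exchange on the fused core at the cyclopentylamine stage

The source may report more compounds than this note shows. Statements on the series, on what has been measured and on what is new or still open speak of the compounds shown alone.

Among the compounds with values here, compound 2 `Cc1cc(C)c(-c2c(C)nn3c(NCCNC4CCCC4)cc(C)nc23)c(C)c1` gives 21 nM in an in vitro assay on Sf9 cells for displacement of a labelled ligand from Neuropeptide Y receptor type 1 (Homo sapiens) (a lower number here means a stronger inhibitor, a higher number a weaker inhibitor), and stands at the lowest of the two numbers measured so far; its nearest neighbour is compound 1 `Cc1cc(C)c(-c2c(C)nn3c(NCCN)cc(C)nc23)c(C)c1`, which in this assay gives 2300 nM. Within the data shown here, the single measured step, a 110-fold lower number from compound 1 to compound 2 (2.04 log units; beyond the scatter), concerns the substituent on the amine nitrogen and leaves the aryl group untouched. Compound 3 `Cc1cc(NCCNC2CCCC2)n2nc(C)c(-c3c(Cl)cccc3Cl)c2n1` keeps that amine and alters the aryl group instead: 2,6-dichlorophenyl in place of 2,4,6-trimethylphenyl on an aromatic carbon. Among the measured compounds shown here, no measured pair shows what this exchange does, so the one step at hand does not bear on it. With nothing to guide the direction, the expectation is a step no larger than the usual scatter, a 1.2-fold higher number from compound 2 to compound 3 (0.08 log units; within the scatter), either way. Compound 3 is therefore estimated at 25 nM in this assay, with a range from 7 nM to 90 nM.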

Compound 3, inhibition constant: 38 nM
Compound 3: middle estimate off by 1.5-fold (0.18 log units), on the low side; the measured number falls inside the stated range.
By their numbers in this assay, from the lowest: compounds 2 and 3 (each within the scatter of the next); then compound 1.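

In this assay the exchange of 2,4,6-trimethylphenyl for 2,6-dichlorophenyl on this aromatic carbon gives a 1.8-fold higher number from compound 2 to compound 3 (0.26 log units; within the scatter) and so leaves the two aryl groups indistinguishable at the cyclopentylamine stage. The earlier step concerned only the amine nitrogen; this one shows that, with the cyclopentyl group held, the position accepts two chlorine atoms in place of three methyl groups, with 8 heavy atoms entering for 9 leaving. No available evidence bears on why the two aryl groups read alike.

Open, from the compounds shown here alone, is whether a phenyl group carrying a single methoxy group, or a pyridine ring, on this aromatic carbon would stay within the scatter of compound 2. Also open, going by these compounds, is whether the same aryl exchange reads alike on the primary amine of compound 1.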